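The compounds below may be only part of what the source reports. "The series", "measured", "known", "first", "only" and "open" are said of these compounds alone.

Measured in a functional assay on HepG2 cells (Homo sapiens) for antiproliferative activity, read by MTT assay, with a stated time of 48 h; on this read-out higher numbers stand for weaker inhibition of growth and lower numbers for stronger inhibition of growth:
- compound 1 `CCCCCN(Cc1ccc(C(=O)NO)cc1)c1ncc(-c2ccc(C)cc2)s1`: 7020 nM
- compound 2 `CCN(Cc1ccc(C(=O)NO)cc1)c1ncc(-c2ccc(C)cc2)s1`: 1120 nM
- compound 3 `CCCCCCCCN(Cc1ccc(C(=O)NO)cc1)c1ncc(-c2ccc(C)cc2)s1`: 8760 nM

Compound 3 stands level with compound 1, as the step between them is small: a 1.2-fold higher number from compound 1 to compound 3 (0.10 log units; within the scatter). The clear gap lies with compound 2, which carries the shortest chain: a 7.8-fold higher number from compound 2 to compound 3 (0.89 log units; beyond the scatter). The matching step on the other side is a 6.3-fold lower number from compound 1 to compound 2 (0.80 log units; beyond the scatter).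

Compound 4 `Cc1ccc(OCCCCN(Cc2ccc(C(=O)NO)cc2)c2ncc(-c3ccc(C)cc3)s2)cc1` keeps the shared core and alters only the far part of the chain: 4-methylphenoxy in place of butyl on a saturated chain carbon, four bonds along the chain from a nitrogen on an aromatic ring. Within the data shown here, no measured compound has a ring on this chain, so the data cannot test that feature directly. The nearest evidence is the lengthening of the chain. The shorter chain differs clearly from both longer ones, but the two longer chains do not differ beyond the scatter. Compound 4 also has a long chain, so it is expected to stay near compound 3 and compound 1, with no step beyond the scatter in this assay. The expected step is a 1.3-fold lower number from compound 3 to compound 4 (0.10 log units; within the scatter). The estimate for compound 4 is 7000 nM, with an expected range of 2500 nM to 18000 nM.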

Compound 4, concentration for 50% growth inhibition: 11000 nM
Compound 4: middle estimate off by 1.6-fold (0.20 log units), on the low side, and the stated range covers the measured number.
By their numbers in this assay, from the lowest: compound 2; then compounds 1, 3 and 4 (each within the scatter of the next).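

In this assay, 4-methylphenoxy in place of butyl, four bonds along the chain from a nitrogen on an aromatic ring, gives a 1.3-fold higher number from compound 3 to compound 4 (0.10 log units; within the scatter) and, set against the pentyl chain, a 1.6-fold higher number from compound 1 to compound 4 (0.20 log units; within the scatter) in this comparison, so an aromatic ring and an oxygen at this position leave the number within the scatter of the plain chains. Compound 4 also stays apart from the shortest chain, with a 9.8-fold higher number from compound 2 to compound 4 (0.99 log units; beyond the scatter) as the step, so a ring-bearing long chain joins the plain long chains on the far side of that gap. Nothing measured on these compounds offers a reason for either result.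

Propyl and butyl chains on the same nitrogen would show where, from ethyl to pentyl, the gap opens. Going by these compounds, an amine or a carboxylic acid at the end of the chain also remains open.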